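A few compounds are considered here, and "the series" means these few. Any claim that something is new, unique, unknown or untested is made for them only; others in the source may bear on it.

Compound 1 `CCN(CC)CN1C(=O)/C(=N/NC(=S)Nc2ccc(Cl)cc2)c2ccccc21` gives 800 nM in an ADME assay on MDCK cells (Canis lupus familiaris) for cytotoxicity; a lower number here means that less compound is tolerated, a higher number that more compound is tolerated.
Compound 2 `CCN(CC)CN1C(=O)/C(=N/NC(=S)Nc2ccc(C)cc2)c2ccccc21` gives 800 nM in this assay.
Compound 3 `CCN(CC)CN1C(=O)/C(=N/NC(=S)Nc2ccc(C)cc2)c2cc(Cl)ccc21` gives 4000 nM in this assay.

Compound 1 differs from compound 2 by chloro in place of methyl on an aromatic carbon, and in this assay this gives no change at the digits printed from compound 2 to compound 1 (within the scatter). Compound 3 differs from compound 2 in the core by chloro in place of hydrogen on an aromatic carbon, which gives a 5.0-fold higher number from compound 2 to compound 3 (0.70 log units; beyond the scatter). Compound 4 `CCN(CC)CN1C(=O)/C(=N/NC(=S)Nc2ccc(Cl)cc2)c2cc(Cl)ccc21` carries the core of compound 3 and differs from it by chloro in place of methyl on an aromatic carbon, the same change that was made from compound 2 to compound 1, since the place is the same in both cases. Because no change at the digits printed from compound 2 to compound 1 (within the scatter) showed nothing beyond the scatter, the expected step in this assay is no change at the digits printed from compound 3 to compound 4 (within the scatter). Among the compounds with values here, compound 4 is therefore estimated at 4000 nM, with a range from 2000 nM to 8000 nM, though only one prior example of the change supports this.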

Compound 4, minimum cytotoxic concentration: >= 800 nM
Compound 4: a limit, no number (the forecaster's own chance of this, stated with the estimate: 5%); the middle value does not contradict the limit.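

In this assay compound 4 gives >= 800 nM, which is a limit of the assay and not a number. Chloro in place of hydrogen on an aromatic carbon gives a number no lower from compound 1 to compound 4 (the limit leaves the size open), so the second case shows no drop in the number, but it cannot show whether the size of the earlier step carries over: the same change on two cores in this assay, a 5.0-fold higher number (0.70 log units; beyond the scatter) from compound 2 to compound 3 and a number no lower (the limit leaves the size open) from compound 1 to compound 4; the limit leaves it open whether they differ The step from compound 3 to compound 4 cannot be read, so the swap of methyl for chloro remains tested by a single readable pair.

The compounds shown leave open how a nitrile or a carboxylic acid would behave in the place of the methyl or chloro group. They also leave open what an amine other than the one shared here would do.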